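This account rests on a few compounds, and the source may have more. Where it says the series, first, only, none or still open, it means among the compounds named here.

Three difluorophenyl isomers sharing one core have so far been measured in a functional assay on A549 cells (Homo sapiens) for cytotoxicity, read by XTT assay, with a stated time of 24 h; a lower number here means a stronger inhibitor, a higher number a weaker inhibitor. Compound 1 (`Fc1cccc(/C=N/NC(=S)Nc2cccc3ccccc23)c1F`), which carries 2,3-difluorophenyl, gives 500 ug/mL. Compound 2 (`Fc1cc(F)cc(/C=N/NC(=S)Nc2cccc3ccccc23)c1`), which carries 3,5-difluorophenyl, gives 500 ug/mL. Compound 3 (`Fc1cccc(F)c1/C=N/NC(=S)Nc1cccc2ccccc12`), which carries 2,6-difluorophenyl, gives 500 ug/mL and so stands level with the other two at the digits reported.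

Compound 4 (`Fc1ccc(/C=N/NC(=S)Nc2cccc3ccccc23)cc1F`) has the same atoms as compound 3, joined differently. On a carbon with a double bond to nitrogen, 3,4-difluorophenyl stands in place of 2,6-difluorophenyl: 3,4-difluorophenyl in place of 2,6-difluorophenyl on a carbon with a double bond to nitrogen.

The measured steps that bear on this change are the exchanges among the three isomers: no change at the digits printed from compound 1 to compound 2 (within the scatter), no change at the digits printed from compound 1 to compound 3 (within the scatter) and no change at the digits printed from compound 2 to compound 3 (within the scatter). All three lie within the usual scatter, although they cover only three arrangements and none of them includes 3,4-difluorophenyl. On that evidence, no step beyond the scatter is expected in this assay, and no direction is favoured. The expected step is no change at the digits printed from compound 3 to compound 4 (within the scatter). Compound 4 is estimated at 500 ug/mL, with an expected range from 250 ug/mL to 600 ug/mL.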

Compound 4, half-maximal inhibitory concentration: 125 ug/mL
Estimate against measurement, compound 4: 4.0-fold (0.60 log units) above; measured number below the stated range.
By their numbers in this assay, from the lowest: compound 4; then compounds 1, 2 and 3 (each within the scatter of the next).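

In this assay the arrangement of the two fluorines on the phenyl group at this carbon with a double bond to nitrogen now proves to matter, which the three earlier isomers, all within the scatter of one another, had not shown: the change to 3,4-difluorophenyl gives a 4.0-fold lower number from compound 3 to compound 4 (0.60 log units; beyond the scatter), and likewise a 4.0-fold lower number from compound 2 to compound 4 (0.60 log units; beyond the scatter) and a 4.0-fold lower number from compound 1 to compound 4 (0.60 log units; beyond the scatter). The step is modest, but all three comparisons lie beyond the scatter, so compound 4 is the most potent of the four, although the group that enters has the same heavy atoms and the same ring as each group it replaces. Nothing available accounts for this difference between the isomers.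

The compounds shown leave open whether the lower number depends on both fluorines of the 3,4-difluorophenyl group or on only one of them, as a phenyl group carrying a single fluorine could show. They also leave open whether the same arrangement would hold with other groups in its place, such as 3,4-dichlorophenyl or 3,4-dimethoxyphenyl.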